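The compounds below may be only part of what the source reports. "The series", "measured", "known", "first", "only" and "open" are said of these compounds alone.

Working notes on a small series sharing the core of compound 1 `O=C(Nc1cccc(F)c1)c1cncc(N2CC3CC(C2)N3)c1`, varied only in the aryl group on the amide-type nitrogen and tested in an assay on cells for displacement of a labelled ligand from Neuronal acetylcholine receptor; alpha3/beta4 (Homo sapiens); on this read-out lower numbers stand for stronger inhibition and higher numbers for weaker inhibition. Compound 1 gives 28 nM. Compound 2 `O=C(Nc1ccccc1)c1cncc(N2CC3CC(C2)N3)c1` gives 192 nM in this assay, and compound 3 `O=C(Nc1ccc(Cl)cc1)c1cncc(N2CC3CC(C2)N3)c1` gives 123 nM. Compound 3 stands second highest of the three numbers: its nearest neighbour is compound 2, with a 1.6-fold lower number from compound 2 to compound 3 (0.19 log units; within the scatter), and the furthest is compound 1, with a 4.4-fold higher number from compound 1 to compound 3 (0.64 log units; beyond the scatter).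

Compound 4 `O=C(Nc1cccc(Cl)c1)c1cncc(N2CC3CC(C2)N3)c1` differs from compound 3 by 3-chlorophenyl in place of 4-chlorophenyl on an amide-type nitrogen. Going by the values given here, two measured steps bear on this. Hydrogen in place of fluoro on the aromatic carbon gave a 6.9-fold higher number from compound 1 to compound 2 (0.84 log units; beyond the scatter), a modest step beyond the scatter. Chloro in place of hydrogen on the aromatic carbon gave a 1.6-fold lower number from compound 2 to compound 3 (0.19 log units; within the scatter), not beyond the scatter. Going by these compounds, compound 4 carries 3-chlorophenyl, matching the substitution pattern of the 3-fluorophenyl of compound 1, though the halogen differs and that swap is untested here. The expectation for compound 4 is therefore a modest step towards lower numbers, a 3.1-fold lower number from compound 3 to compound 4 (0.49 log units; beyond the scatter). Compound 4 is estimated at 40 nM, with a range from 15 nM to 120 nM.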

Compound 4, inhibition constant: 59 nM
The estimate for compound 4 lay 1.5-fold (0.17 log units) below the measured number, within the range that was stated.
By their numbers in this assay, from the lowest: compound 1; then compound 4; then compounds 3 and 2 (each within the scatter of the next).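

Going by these compounds alone, with the same atoms on the amide-type nitrogen, 3-chlorophenyl in place of 4-chlorophenyl gives a 2.1-fold lower number from compound 3 to compound 4 (0.32 log units; beyond the scatter), so in this assay the place of the chlorine on the ring counts, which the earlier compounds could not show. Chloro in place of hydrogen gives a 3.3-fold lower number from compound 2 to compound 4 (0.51 log units; beyond the scatter) when it forms 3-chlorophenyl, whereas forming 4-chlorophenyl gave no change beyond the scatter. The halogen also counts at this place: chloro in place of fluoro gives a 2.1-fold higher number from compound 1 to compound 4 (0.32 log units; beyond the scatter), which leaves 3-fluorophenyl with the lowest number of the four.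

No measurement at hand gives a reason for these differences. Going by these compounds, what 4-fluorophenyl, 3-bromophenyl or 3-methoxyphenyl would give on the amide-type nitrogen remains open.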